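Shortening the chain end of compound 2 toward a hydroxyl

This account rests on a few compounds, and the source may have more. Where it says the series, first, only, none or still open, it means among the compounds named here.

Compound 2 `CC(C)(C)OC(=O)NCCNC(=O)CN1CN(c2ccccc2)C2(CCN(C(=O)c3ccc(C4CCCCC4)cc3)CC2)C1=O` gives 5500 nM in an assay on HEK293 cells for displacement of a labelled ligand from NPC1-like intracellular cholesterol transporter 1 (Homo sapiens) (a higher number here means a weaker inhibitor, a lower number a stronger inhibitor), the lowest of the three numbers shown. Compound 1 `CC(C)(C)OC(=O)NCCNC(=O)CN1CN(c2ccccc2)C2(CCN(C(=O)c3ccc(C(C)(C)C)cc3)CC2)C1=O` gives 10900 nM, and a 2.0-fold lower number from compound 1 to compound 2 (0.30 log units; within the scatter). Compound 3 `CC(C)(C)c1ccc(C(=O)N2CCC3(CC2)C(=O)N(CC(=O)NCCCCN)CN3c2ccccc2)cc1` gives 14500 nM, a number beyond the scatter from that of compound 2. Compound 4 `O=C(CN1CN(c2ccccc2)C2(CCN(C(=O)c3ccc(C4CCCCC4)cc3)CC2)C1=O)NCO` is not yet measured. It differs from compound 2 in one place: hydroxy in place of ((tert-butoxycarbonyl)amino)methyl on a saturated chain carbon bound to an amide-type nitrogen.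

Among the measured compounds shown here, only one measured step touches the same part of the molecule: a 1.3-fold higher number from compound 1 to compound 3 (0.12 log units; within the scatter), where the chain kept its length but lost its (tert-butoxycarbonyl)amino end. That change stayed within the scatter. For the measured compounds named here, the step to compound 4 removes more, yet nothing among the measured compounds suggests that this chain end carries much of the binding. The expectation is therefore a small step, if any, with a slight lean toward a higher number, and a 1.4-fold higher number from compound 2 to compound 4 (0.13 log units; within the scatter) is what is estimated. Compound 4 is expected to give about 7500 nM in this assay, with a range from 3000 nM to 18000 nM.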

Compound 4, half-maximal inhibitory concentration: 8300 nM
Estimate against measurement, compound 4: 1.1-fold (0.04 log units) below, within the range that was stated.
By their numbers in this assay, from the lowest: compounds 2, 4, 1 and 3 (each within the scatter of the next, the first and the last beyond it).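

In this assay, putting hydroxy in place of ((tert-butoxycarbonyl)amino)methyl on a saturated chain carbon bound to an amide-type nitrogen gives a 1.5-fold higher number from compound 2 to compound 4 (0.18 log units; within the scatter), even though 9 heavy atoms leave and only 1 enters. The earlier step at this chain end kept the chain length and carried the tert-butyl group, whereas this one shortens the chain and carries the cyclohexyl group, and it still stays within the scatter. Nothing shown explains this result.

The compounds shown leave open whether a carboxylic acid or a primary amine at this chain end would also stay within the scatter alongside the cyclohexyl group. A longer chain ending in hydroxy, or a methyl in place of the whole chain on the amide nitrogen, also remains to be seen.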